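Swapping 4-Chlorophenyl for Thiophen-3-yl: Expected Cytotoxicity

The compounds below may be only part of what the source reports. "The series", "measured", "known", "first", "only" and "open" are said of these compounds alone.

Compound 1, `COc1ccc(-c2cnc(Nc3ccc(C#N)cc3)nc2Oc2c(C)cc(C#N)cc2C)cc1`, in an ADME assay on MT4 cells (Homo sapiens) for cytotoxicity, read by MTT assay, with a stated time of 5 days; on this read-out lower numbers stand for higher toxicity in this test and higher numbers for lower toxicity in this test: > 279000 nM, a limit of the assay rather than a number.
Compound 2, `Cc1cc(C#N)cc(C)c1Oc1nc(Nc2ccc(C#N)cc2)ncc1-c1ccc(Cl)cc1`, in this assay: 72600 nM.

Among the measured compounds shown here, compound 2 thus gives the only actual number seen here, as stated under the limit of > 279000 nM in this assay, at which 1 of the 2 values shown sits, where the other value sits. Compound 3, `Cc1cc(C#N)cc(C)c1Oc1nc(Nc2ccc(C#N)cc2)ncc1-c1ccsc1`, differs from compound 2 in one place: thiophen-3-yl in place of 4-chlorophenyl on an aromatic carbon. For the measured compounds named here, the only measured step, an at least 3.8-fold lower number from compound 1 to compound 2 (0.58 log units; beyond the scatter), concerns a different exchange, chloro in place of methoxy, on the very 4-chlorophenyl group that is now replaced as a whole, so it does not carry over to the present change. Going by the values given here, with no step bearing on it, the expectation stays cautious and wide. Compound 3 is estimated at 100000 nM, with a range from 30000 nM to 350000 nM. That estimate means a step of a 1.4-fold higher number from compound 2 to compound 3 (0.14 log units; within the scatter), expected to remain within the scatter, while leaving room for the assay to report only a limit again.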

Compound 3, half-maximal cytotoxic concentration: 3920 nM
Estimate against measurement, compound 3: 26-fold (1.41 log units) above, and the stated range ends above it.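

In this assay, among the compounds shown here, this position proves sensitive to the ring it carries, not only to the group on that ring: the earlier compounds kept the phenyl ring and changed only its substituent, whereas replacing the whole ring gives a 19-fold lower number from compound 2 to compound 3 (1.27 log units; beyond the scatter), a large step well beyond the scatter. The same holds against the methoxy-bearing compound, with an at least 71-fold lower number from compound 1 to compound 3 (1.85 log units; beyond the scatter), so compound 3, with thiophen-3-yl, has the lowest number of the three and is the most toxic in this test. The figure for compound 1 is a limit of the assay, not a number: the limit of > 279000 nM in this assay, at which 1 of the 3 values shown sits.

The exchange alters several things at once, since a six-membered carbon ring gives way to a five-membered ring holding sulfur and the chloro group disappears, and these three compounds cannot show which of these differences accounts for the step. As far as these compounds go, whether the lower number belongs to thiophen-3-yl in particular or would also appear with an unsubstituted phenyl, a thiophen-2-yl or a furan-3-yl group at this carbon remains open.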